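Swapping 4-(tert-butyl)phenyl for pyridin-3-yl on the shared core

The compounds below may be only part of what the source reports. "The series", "measured", "known", "first", "only" and "open" are said of these compounds alone.

Of the compounds shown here, three on one core have been measured in a functional assay on A549 cells (Homo sapiens) for antiproliferative activity, with a stated time of 72 h; a lower number here means a stronger inhibitor, a higher number a weaker inhibitor. Compound 1 `C/C(=C\c1csc(C)n1)[C@@H]1C[C@@H]2OC(c3ccc(C)cc3)=N[C@H]2CCC[C@H](C)[C@H](O)[C@@H](C)C(=O)C(C)(C)[C@@H](O)CC(=O)O1`, with a methyl on its aromatic ring, gives 2.9 nM. Compound 2 `C/C(=C\c1csc(C)n1)[C@@H]1C[C@@H]2OC(c3ccc(C(C)C)cc3)=N[C@H]2CCC[C@H](C)[C@H](O)[C@@H](C)C(=O)C(C)(C)[C@@H](O)CC(=O)O1`, with isopropyl in place of that methyl, gives 4870 nM. That change is a 1700-fold higher number from compound 1 to compound 2 (3.23 log units; beyond the scatter). Compound 3 `C/C(=C\c1csc(C)n1)[C@@H]1C[C@@H]2OC(c3ccc(C(C)(C)C)cc3)=N[C@H]2CCC[C@H](C)[C@H](O)[C@@H](C)C(=O)C(C)(C)[C@@H](O)CC(=O)O1`, with tert-butyl there, gives > 10000 nM, which is a limit of the assay and not a number. The change to tert-butyl is an at least 3400-fold higher number from compound 1 to compound 3 (3.53 log units; beyond the scatter), and the last increment is an at least 2.0-fold higher number from compound 2 to compound 3 (0.31 log units; beyond the scatter). Compound 3 therefore stands at the weak end of the three.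

Compound 4 `C/C(=C\c1csc(C)n1)[C@@H]1C[C@@H]2OC(c3cccnc3)=N[C@H]2CCC[C@H](C)[C@H](O)[C@@H](C)C(=O)C(C)(C)[C@@H](O)CC(=O)O1` differs from compound 3 by pyridin-3-yl in place of 4-(tert-butyl)phenyl on a carbon with a double bond to nitrogen. Going by the values given here, no measured step tests the hetero atom in the ring, so the evidence is indirect. The closest guide is the reverse of an at least 3400-fold higher number from compound 1 to compound 3 (3.53 log units; beyond the scatter), since compound 4 also lacks the tert-butyl group. A large step towards a lower number in this assay is therefore expected, namely an at least 660-fold lower number from compound 3 to compound 4 (2.82 log units; beyond the scatter). Compound 4 is expected to give an estimated 15 nM, within a range of 2 nM to 150 nM.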

Compound 4, half-maximal inhibitory concentration: 0.92 nM
The estimate for compound 4 lay 16-fold (1.21 log units) above the measured number; measured number outside the range, below it.
By their numbers in this assay, from the lowest: compound 4; then compound 1; then compound 2. At a limit, above all of these: compound 3.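

The earlier compounds shown here showed only that this position, the carbon with a double bond to nitrogen, lost activity once the methyl on the phenyl ring gave way to isopropyl or tert-butyl; compound 4 shows that a ring with a hetero atom and no alkyl group is accepted there and gives the lowest number of the four in this assay, a modest gain of a 3.2-fold lower number from compound 1 to compound 4 (0.50 log units; beyond the scatter). Against the larger groups the same change spans almost the whole range seen at this position, with a 5300-fold lower number from compound 2 to compound 4 (3.72 log units; beyond the scatter) and an at least 10000-fold lower number from compound 3 to compound 4 (4.03 log units; beyond the scatter). The value of compound 3 is a limit of the assay and not a number, so the last of these steps is only a bound: the limit of > 10000 nM in this assay, at which 1 of the 4 values shown sits.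

Going from 4-methylphenyl to pyridin-3-yl both removes the methyl and brings in the ring nitrogen, and the compounds shown cannot separate these two parts of the change; an unsubstituted phenyl or a methylpyridine would. Also open, from the compounds shown here alone, is how pyridin-2-yl, pyridin-4-yl or a phenyl ring carrying an amine would behave at this position.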